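Moving a methyl around a benzyl ether: compound 3

The source may report more compounds than this note shows. Statements on the series, on what has been measured and on what is new or still open speak of the compounds shown alone.

Compound 2 `Cc1cccc(COc2ccc(C3=NN(CCC#N)C(=O)CO3)cc2)c1`: 40000 nM
Compound 1 `N#CCCN1N=C(c2ccc(OCc3ccccc3)cc2)OCC1=O`: 160000 nM

Of the compounds shown here, two have been measured in an assay for inhibition of Amine oxidase [flavin-containing] A (Rattus norvegicus); a lower number here means a stronger inhibitor, a higher number a weaker inhibitor. Compound 1 `N#CCCN1N=C(c2ccc(OCc3ccccc3)cc2)OCC1=O` gives 160000 nM, while compound 2 `Cc1cccc(COc2ccc(C3=NN(CCC#N)C(=O)CO3)cc2)c1` gives 40000 nM. Going by the values given here, the one counted step is a 4.0-fold lower number from compound 1 to compound 2 (0.60 log units; beyond the scatter). Among the compounds with values here, on these two numbers compound 2 stands lowest, with compound 1 the only neighbour and a larger number.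

Compound 3 `Cc1ccc(COc2ccc(C3=NN(CCC#N)C(=O)CO3)cc2)cc1` differs from compound 2 by 4-methylphenyl in place of 3-methylphenyl on a saturated chain carbon bound to an oxygen on an aromatic ring. Within the data shown here, no measured step bears on this rearrangement directly; the only step in hand, from compound 1 to compound 2, shows that a methyl on this ring matters, but says nothing about shifting it. The expectation is therefore a step in this assay of about no change at the digits printed from compound 2 to compound 3 (within the scatter), with no direction clearly favoured beyond the scatter. Compound 3 is accordingly estimated at 40000 nM, within a range of 10000 nM to 160000 nM.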

Compound 3, half-maximal inhibitory concentration: 250000 nM
The estimate for compound 3 lay 6.3-fold (0.80 log units) below the measured number; the whole stated range lies below it.
By their numbers in this assay, from the lowest: compound 2; then compounds 1 and 3 (each within the scatter of the next).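

In this assay, the place of the methyl on the benzyl ether turns out to matter, not just its presence: going from 3-methylbenzyl to 4-methylbenzyl gives a 6.3-fold higher number from compound 2 to compound 3 (0.80 log units; beyond the scatter). The gain seen earlier with a methyl therefore does not hold for every place on this ring, since adding the methyl as 4-methylphenyl gives a 1.6-fold higher number from compound 1 to compound 3 (0.19 log units; within the scatter). Nothing at hand accounts for the difference between the two placements.

The compounds shown leave open whether this preference is particular to methyl, which a 3-methoxyphenyl or 3-chlorophenyl group on the same saturated chain carbon would test. They also leave open whether the order of the 3-methylphenyl and 4-methylphenyl compounds would hold if the nitrile chain on the shared core were replaced by a longer chain or an amine.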